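The source may report more compounds than this note shows. Statements on the series, on what has been measured and on what is new or still open speak of the compounds shown alone.

Three compounds that share a core bearing a chlorine, with a chain attached to one of its aromatic nitrogens, have been tested for how strongly they slow the growth of a colon cancer cell line. Compound 1 `CCCC(CCO)n1cnc2c(Cl)ncnc21` carries a hydroxyethyl arm and a propyl arm on the chain carbon. In a functional assay on SW480 cells (Homo sapiens) for antiproliferative activity, read by MTT assay, with a stated time of 48 h (a lower number here means a stronger inhibitor, a higher number a weaker inhibitor), compound 1 gives only a limit of the assay, > 50000 nM. Compound 2 `CCCCC(CCO)n1cnc2c(Cl)ncnc21` differs from it by methyl in place of hydrogen on a saturated chain carbon, four bonds along the chain from an aromatic nitrogen. In this assay compound 2 likewise gives only a limit, > 50000 nM. The step that the two limits leave unreadable from compound 1 to compound 2 cannot be sized, because the limit of > 50000 nM in this assay, at which 2 of the 3 values shown sit, hides whatever change there was. Compound 3 `CCCCCCC[C@@H](CCO)n1cnc2c(Cl)ncnc21` carries a much longer chain; the difference between its core and that of compound 1 is not broken down here. In this assay, among the measured compounds shown here, compound 3 gives 3820 nM, the one plain number so far.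

Compound 4 `CCCCCCCC[C@@H](CCO)n1cnc2c(Cl)ncnc21` differs from compound 3 by methyl in place of hydrogen on a saturated chain carbon, eight bonds along the chain from an aromatic nitrogen, the same kind of change as that from compound 1 to compound 2, but eight bonds rather than four bonds along the chain from the aromatic nitrogen. Since compound 3, with its long chain, is the compound that reaches a measurable value of 3820 nM, a further single carbon is expected to move potency little, and the step of a 1.4-fold lower number from compound 3 to compound 4 (0.13 log units; within the scatter) is estimated to stay within usual scatter. Compound 4 is therefore expected to give about 2800 nM in this assay, most likely between 900 nM and 8000 nM.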

Compound 4, half-maximal inhibitory concentration: 2330 nM
Beside the measured number, compound 4's estimate is 1.2-fold (0.08 log units) above it; the range from low to high includes it.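

In this assay, methyl in place of hydrogen on a saturated chain carbon, eight bonds along the chain from an aromatic nitrogen, gives a 1.6-fold lower number from compound 3 to compound 4 (0.21 log units; within the scatter), so on this long chain the extra carbon leaves the reading within the usual scatter. The same kind of change, four bonds along the chain, cannot be read from compound 1 to compound 2 because both compounds give only a limit of the assay: the limit of > 50000 nM in this assay, at which 2 of the 4 values shown sit. With a single readable step, the series does not show whether the change behaves alike from one compound pair to another, so the result on compound 3 cannot be carried over to compound 1.

The compounds shown leave open how a still longer chain would read in this assay, and whether the small step seen here would persist on it. They also leave open what an amine or a carboxylic acid would do in place of the hydroxyl group of the hydroxyethyl arm.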